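The source may report more compounds than this note shows. Statements on the series, on what has been measured and on what is new or still open speak of the compounds shown alone.

Of the compounds shown here, three have been tested in a functional assay on a cell-free system (Platelet, plasma, Homo sapiens) for inhibition (a lower number here means a stronger inhibitor, a higher number a weaker inhibitor), all built on one shared core that carries an acid-bearing chain on a saturated chain carbon bound to an amide-type nitrogen in a ring. Compound 1 `O=C(O)CCN1Cc2ccc(NC(=O)c3ccc(C4CCNCC4)cc3)cc2C1=O` gives 9600 nM. Compound 2 `CC(CC(=O)O)N1Cc2ccc(NC(=O)c3cccc(N4CCNCC4)c3)cc2C1=O`, which differs from the others at several points, gives 62000 nM. Compound 3 `O=C(O)CN1Cc2ccc(NC(=O)c3ccc(C4CCNCC4)cc3)cc2C1=O` gives 24000 nM, which places compound 3 second highest of the three numbers, with compound 1 nearest and compound 2 furthest.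

Among the compounds with values here, the one single-point step among the measured compounds runs a 2.5-fold higher number from compound 1 to compound 3 (0.40 log units; beyond the scatter), so trimming the chain by one carbon weakened inhibition modestly.

Compound 4 `O=C(O)CCCN1Cc2ccc(NC(=O)c3ccc(C4CCNCC4)cc3)cc2C1=O` goes the other way from compound 3: 2-carboxyethyl in place of carboxy on a saturated chain carbon bound to an amide-type nitrogen in a ring. This lengthens the chain by two carbons, passing beyond compound 1. Within the data shown here, since the shortening from compound 1 to compound 3 cost a 2.5-fold higher number from compound 1 to compound 3 (0.40 log units; beyond the scatter), the reverse direction is expected to return a lower number, plausibly near compound 1 or somewhat past it, though no measured step covers the extra carbon. The step from compound 3 to compound 4 is therefore expected to be a 3.0-fold lower number from compound 3 to compound 4 (0.48 log units; beyond the scatter). In this assay compound 4 is estimated at 8000 nM, within a range from 3000 nM to 25000 nM.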

Compound 4, half-maximal inhibitory concentration: 410000 nM
For compound 4 the middle estimate is 51-fold (1.71 log units) below the measured one; measured number above the stated range.
By their numbers in this assay, from the lowest: compound 1; then compound 3; then compound 2; then compound 4.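

The earlier compounds shown here suggested that a longer chain on the acid might simply help, but in this assay the 3-carboxypropyl chain of compound 4 ends that reading, with a 17-fold higher number from compound 3 to compound 4 (1.23 log units; beyond the scatter). Compound 1, with the 2-carboxyethyl chain, now has a higher number on neither side: shortening gives a 2.5-fold higher number from compound 1 to compound 3 (0.40 log units; beyond the scatter), while lengthening gives a 43-fold higher number from compound 1 to compound 4 (1.63 log units; beyond the scatter). Among these three compounds, then, the chain length of compound 1 gives the lowest number, and the penalty is much larger for going longer than for going shorter, so this position tolerates the longer chain poorly even though only the chain length changes.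

Nothing at hand explains why the longer chain costs so much. Still open, on these data alone, is whether the acid itself is needed at this position, which a primary amide or a tetrazole at the end of the 2-carboxyethyl chain would test, and whether a methyl group on that chain would change the number when the rest of compound 1 stays the same.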